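The source may hold more compounds than are shown below. What is called first, only, known or untested is meant among the compounds shown, and "the series" means these compounds.

Measured so far in an ADME assay on HEp-2 cells (Homo sapiens) for cytotoxicity, read by CCK-8 assay, with a stated time of 6 days; on this read-out lower numbers stand for higher toxicity in this test and higher numbers for lower toxicity in this test:
- compound 1, `NCCNc1cc(N2CCN(C(=O)C3(c4ccccc4)CCC3)CC2)nc2ccccc12`: > 100000 nM
- compound 2, `CC(C)C(=O)N1CCN(c2cc(NCCN)c3ccccc3n2)CC1`: > 100000 nM

In this assay compound 1 gives > 100000 nM, which is a limit of the assay and not a number. Compound 2 gives > 100000 nM, again a limit. The step that the two limits leave unreadable from compound 1 to compound 2 therefore cannot be sized. Compound 2 stands where both values shown sit, namely at the limit of > 100000 nM in this assay, at which 2 of the 2 values shown sit, and nothing more precise can be said of its position.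

Compound 3, `NCCNc1cc(N2CCN(C(=O)C3CCCCC3)CC2)nc2ccccc12`, differs from compound 2 by cyclohexyl in place of isopropyl on a carbonyl carbon. Among the compounds with values here, the only measured step that touches this position is a step that the two limits leave unreadable from compound 1 to compound 2, which exchanged one carbonyl substituent for another without leaving the limit; it gives no readable size and no direction. There is thus no basis for expecting a step beyond the scatter in this assay, and the expectation is that compound 3 will also sit at the limit.

Compound 3 is accordingly estimated at 100000 nM, with a range from 30000 nM to 300000 nM. The step of a number no higher from compound 2 to compound 3 (the limit leaves the size open) that this estimate implies is expected to be none beyond the scatter.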

Compound 3, half-maximal cytotoxic concentration: > 100000 nM
Compound 3: no number, only a limit; the forecaster's own chance of this, stated with the estimate: 80%; the middle value lies on the limit itself.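

In this assay compound 3 gives > 100000 nM, which is a limit of the assay and not a number. No new step can be read from compound 3 to compound 1 or compound 2, as all three share one limit: the limit of > 100000 nM in this assay, at which 3 of the 3 values shown sit.

The compounds shown leave open whether the carbonyl substituent matters at all in this test, and what any true value beyond the limit would be.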